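Adding Fluorine to an Inactive Pair

A few compounds are considered here, and "the series" means these few. Any claim that something is new, unique, unknown or untested is made for them only; others in the source may bear on it.

Compound 1 `Fc1cccc(-c2nc(Nc3ccccc3)c3ccccc3n2)c1` and compound 2 `Fc1ccc2nc(-c3ccccc3)nc(Nc3ccccc3)c2c1` share a core. In a functional assay on MCF7 cells (Homo sapiens) for cytotoxicity, read by MTT assay, with a stated time of 48 h (on this read-out lower numbers stand for stronger inhibition and higher numbers for weaker inhibition), compound 1 gives only a limit, > 50000 nM. In this assay compound 2 also gives only a limit, > 50000 nM. Both values sit at the limit of > 50000 nM in this assay, at which 2 of the 2 values shown sit. Compound 3 `Fc1cccc(-c2nc(Nc3ccccc3)c3cc(F)ccc3n2)c1` differs from compound 2 by fluoro in place of hydrogen on an aromatic carbon. Among the compounds with values here, no step between measured compounds is known, and both measured values are limits, so no direction of change can be read. The expected step in this assay is a step that the limit leaves unreadable from compound 2 to compound 3, none beyond the scatter. Compound 3 is estimated at 60000 nM, within 25000 nM to 150000 nM, most likely again reported only as a limit.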

Compound 3, half-maximal inhibitory concentration: 49700 nM
Beside the measured number, compound 3's estimate is 1.2-fold (0.08 log units) above it, within the range that was stated.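

With fluoro on both sides of the shared core, in this assay compound 3 gives 49700 nM as a measured number. This gives the series its first readable value at this position. There is a number no higher from compound 2 to compound 3 (the limit leaves the size open) and a number no higher from compound 1 to compound 3 (the limit leaves the size open) but neither size can be read. Compounds 1 and 2 each remain only a limit: the limit of > 50000 nM in this assay, at which 2 of the 3 values shown sit.

Going by these compounds, whether a second fluoro moves the value beyond the usual scatter therefore stays open. So does whether a chloro group or an amine on that aromatic carbon would bring the number lower.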